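A few compounds are considered here, and "the series" means these few. Any claim that something is new, unique, unknown or untested is made for them only; others in the source may bear on it.

The three measured compounds share a core fused from two rings and each carry a benzyl group bearing a chloromethyl substituent, and all were tested in a functional assay on HCC 2998 cells (Homo sapiens) for cytotoxicity, read by sulforhodamine B assay, with a stated time of 48 h; on this read-out lower numbers stand for higher toxicity in this test and higher numbers for lower toxicity in this test. Compound 1 `ClCc1ccc(Cn2cnc3c(Cl)ncnc32)cc1` gives 5120 nM in this assay, compound 2 `Nc1nc(Cl)c2ncn(Cc3ccccc3CCl)c2n1` gives 26300 nM, and compound 3 `ClCc1ccccc1Cn1cnc2nc(Cl)nc(Cl)c21` gives 66100 nM. Compound 3 thus stands at the highest of the three numbers: its nearest neighbour is compound 2, whose number is lower by a margin beyond the scatter, and compound 1 lies furthest away with a number lower still.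

Compound 4 `ClCc1ccccc1Cn1cnc2ncnc(Cl)c21` differs from compound 3 in a single place: hydrogen in place of chloro on an aromatic carbon. Among the measured compounds shown here, no pair of measured compounds shows this exact change. Compound 1 also carries hydrogen at that site of the core, but it differs from compound 4 elsewhere as well, so its number cannot be read as a measure of this change alone. Even so, both measured compounds that lack the chloro there sit at lower numbers than compound 3. The step from compound 3 to compound 4 is expected to be a 2.2-fold lower number from compound 3 to compound 4 (0.34 log units; beyond the scatter), a move toward a lower number, modest but beyond the scatter. Compound 4 is accordingly estimated at 30000 nM, with a range from 10000 nM to 90000 nM.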

Compound 4, concentration lethal to 50% of the cells: 7940 nM
The estimate for compound 4 lay 3.8-fold (0.58 log units) above the measured number; the whole stated range lies above it.
By their numbers in this assay, from the lowest: compounds 1 and 4 (each within the scatter of the next); then compound 2; then compound 3.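

Among the compounds shown here, replacing the chloro with hydrogen on this aromatic carbon, which lies between two ring nitrogen atoms, gives an 8.3-fold lower number from compound 3 to compound 4 (0.92 log units; beyond the scatter) in this assay and provides the first reading of this change on its own. For the compounds shown here, no measured pair had differed only here. The step shows that this single chlorine atom has a large bearing on the number while the other chloro group and the benzyl group bearing the chloromethyl substituent stay the same, but nothing measured here explains why the number moves so far.

A single step cannot show whether the number follows the presence of chloro in particular or of any group other than hydrogen on this carbon, a question that a fluoro, a methyl or a methoxy group at the same site would address. The compounds shown also leave open whether this change would give a step of similar size with the benzyl group arranged as in compound 1.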